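Acetylation of the side-chain hydroxyl in the amino series

The compounds below may be only part of what the source reports. "The series", "measured", "known", "first", "only" and "open" are said of these compounds alone.

Measured compounds:
compound 1, `CC(=O)OC(C)n1cnc2c(Cl)nc(I)nc21` — in a functional assay on SW-620 cells (Homo sapiens) for inhibition (a lower number here means a stronger inhibitor, a higher number a weaker inhibitor), compound 1 gives 3550 nM
compound 2, `CC(O)n1cnc2c(N)nc(I)nc21` — in this assay compound 2 gives > 500000 nM

Compound 2 stands at the limit of > 500000 nM in this assay, at which 1 of the 2 values shown sits; for compound 2 the entry > 500000 nM is a limit of the assay and not a number. Among the compounds with values here, compound 1, carrying chlorine in place of the amino group and the acetoxy side chain, is the only compound with a measured number, 3550 nM in this assay.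

Compound 3, `CC(=O)OC(C)n1cnc2c(N)nc(I)nc21`, is not yet measured. It differs from compound 2 by acetyl in place of hydrogen on an oxygen on a saturated carbon. Within the data shown here, no step between measured compounds covers this change, and the amino-to-chlorine difference between compound 2 and compound 1 is confounded with the side-chain change, so the two values cannot be separated into a step.

The expected step from compound 2 to compound 3 in this assay is an at least 3.3-fold lower number from compound 2 to compound 3 (0.52 log units; beyond the scatter), toward stronger inhibition, but uncertain because compound 2 is known only as > 500000 nM. Compound 3 is estimated at 150000 nM in this assay, with a range from 10000 nM to 600000 nM; a further limit-only result remains plausible.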

Compound 3, half-maximal inhibitory concentration: > 500000 nM
Compound 3: no number, only a limit; the forecaster's own chance of this, stated with the estimate: 45%; middle value at least 3.3-fold (0.52 log units) away from the limit.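

In this assay compound 3 gives > 500000 nM, which is a limit of the assay and not a number. Acetoxy in place of hydroxy therefore does not bring the amino series into the readable range, and the step for this change on the oxygen cannot be read, with both amino compounds resting at the same limit: the limit of > 500000 nM in this assay, at which 2 of the 3 values shown sit.

With the acetoxy side chain now held constant, the comparison of amino with chloro on the aromatic carbon is no longer confounded, and it gives an at least 140-fold higher number from compound 1 to compound 3 (2.14 log units; beyond the scatter), so among these compounds a measurable number is seen only with chloro at this position.

Still open, as far as these compounds go, is whether hydroxy to acetoxy changes the number once chloro sits on the aromatic carbon, as the effect of the side chain has so far been examined only in the amino series. Also open, from the compounds shown here alone, is how a methoxy or methylamino group on that carbon would read, and whether a longer ester such as propanoyloxy on the side chain would shift the value of the chloro compound.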